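This account rests on a few compounds, and the source may have more. Where it says the series, first, only, none or still open, it means among the compounds named here.

Compound 1 `Cc1nc2c(/C=C\c3ccccc3)cccn2c1C` stands highest of the three compounds measured: in a functional assay on the whole organism (stomach) for inhibition, with Canis familiaris (Canis lupus familiaris) as the target, at a dose of 8 mg/kg by the oral route (on this read-out higher numbers stand for a stronger effect at the one dose given and lower numbers for a weaker effect), compound 1 gives 74%. Compound 2 `Cc1nc2c(/C=C\c3ccccc3)cccn2c1N` gives 4% and compound 3 `CCc1c(C)nc2c(/C=C\c3ccccc3)cccn12` gives 21%, so that a number 70 percentage points lower from compound 1 to compound 2 (beyond the scatter) and a number 53 percentage points lower from compound 1 to compound 3 (beyond the scatter). Compound 4 `Cc1nc2c(/C=C\c3ccsc3)cccn2c1C` differs from compound 1 by thiophen-3-yl in place of phenyl on a double-bonded chain carbon bound to a double-bonded chain carbon. Neither measured step bears directly on this change: both alter the shared core, whereas the change to compound 4 leaves the core of compound 1 untouched and exchanges only the aromatic ring on the chain. Those steps show that the read-out of compound 1 is sensitive to change, so a drop cannot be ruled out. The step expected is a number 14 percentage points lower from compound 1 to compound 4 (beyond the scatter). Compound 4 is therefore estimated at 60%, within 25% to 85%.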

Compound 4, a percentage reported as inhibition, in the whole organism at one dose (the size of the read-out at that dose, not a potency): 79%
Compound 4: middle estimate off by 19 percentage points, on the low side; the range from low to high includes it.
By their numbers in this assay, from the lowest: compound 2; then compound 3; then compounds 1 and 4 (each within the scatter of the next).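

In this assay, thiophen-3-yl in place of phenyl gives a number 5 percentage points higher from compound 1 to compound 4 (within the scatter), so a five-membered aromatic ring with a sulfur atom can stand on this double-bonded chain carbon without a step beyond the scatter. The two changes to the shared core of compound 1 gave large steps, whereas this exchange on the chain does not. Nothing given here explains this result. The compounds shown leave open whether pyridin-3-yl, thiophen-2-yl or cyclohexyl at this place would hold the read-out.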